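The compounds below may be only part of what the source reports. "The series", "measured", "known", "first", "only" and "open" are said of these compounds alone.

In a functional assay on the whole organism for inhibition, with Rattus norvegicus as the target (on this read-out higher numbers stand for an effect only at larger amounts of compound and lower numbers for an effect already at smaller amounts), compound 1 `CC(C)c1ccc(OC(C)(Cc2cccc(Cl)c2)C(=O)O)cc1` gives 5 mg/kg. Compound 2 `Cc1cccc(CC(C)(Oc2ccc(C(C)C)cc2)C(=O)O)c1` gives < 1 mg/kg, which is a limit of the assay and not a number. Compound 3 `CCc1ccccc1CC(C)(Oc1ccc(C(C)C)cc1)C(=O)O` carries 2-ethylphenyl in place of 3-methylphenyl on a saturated chain carbon, two bonds along the chain from a carbonyl carbon and an oxygen on an aromatic ring.

For the measured compounds named here, only one measured step bears on this change: an at least 5.0-fold lower number from compound 1 to compound 2 (0.69 log units; beyond the scatter), with methyl in place of chloro on an aromatic carbon. Going by the values given here, it lies beyond the scatter and shows that a change on this aromatic ring can shift the read-out, but no measured compound carries 2-ethylphenyl. In this assay a modest move to a higher number is therefore expected, no larger than that measured step. The expected step is an at least 1.5-fold higher number from compound 2 to compound 3 (0.17 log units; that floor lies within the scatter). For compound 3 the estimate is 1.5 mg/kg, with an expected range of 0.4 mg/kg to 5 mg/kg.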

Compound 3, dose for half-maximal effect: 5 mg/kg
Compound 3: the middle estimate sits 3.3-fold (0.52 log units) below what was measured; low and high end bracket the measured number.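

In this assay, replacing 3-methylphenyl with 2-ethylphenyl gives an at least 5.0-fold higher number from compound 2 to compound 3 (0.69 log units; beyond the scatter), so the low number of compound 2 does not extend to every alkyl-bearing phenyl at this place on the saturated chain. Against 3-chlorophenyl, the same group gives no change at the digits printed from compound 1 to compound 3 (within the scatter), which leaves 3-methylphenyl as the only one of the three aryl groups tied to the lower number. The figure for compound 2 is a limit of the assay and not a number, so the first step is a floor: the limit of < 1 mg/kg in this assay, at which 1 of the 3 values shown sits.

Going by these compounds, whether the higher number goes with the ethyl group or with its place on the ring stays open; 3-ethylphenyl and 2-methylphenyl would separate the two. On these data alone, how a methoxy group or an amine on this ring would read is also open, as is the true value of compound 2.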